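Halogen swap on the triazole aryl, compound 3 to compound 4

The compounds below may be only part of what the source reports. "The series", "measured", "known", "first", "only" and "open" are said of these compounds alone.

Series notes. Compound 1 `C=C1C[C@]23C[C@@]1(O)CC[C@H]2c1cc(Br)c(O)c(C)c1[C@@H]3Cn1cc(-c2ccccn2)nn1` carries a pyridin-2-yl on the triazole; in a functional assay on SMMC-7721 cells (Homo sapiens) for cytotoxicity, read by MTT assay, with a stated time of 4 days (a lower number here means a stronger inhibitor, a higher number a weaker inhibitor), compound 1 gives > 20000 nM, which is a limit of the assay and not a number. Compound 2 `C=C1C[C@]23C[C@@]1(O)CC[C@H]2c1cc(Br)c(O)c(C)c1[C@@H]3Cn1cc(-c2ccccc2)nn1` carries phenyl instead; in this assay compound 2 gives > 20000 nM, likewise a limit. Compound 3 `C=C1C[C@]23C[C@@]1(O)CC[C@H]2c1cc(Br)c(O)c(C)c1[C@@H]3Cn1cc(-c2ccc(Cl)cc2)nn1` carries 4-chlorophenyl, and in this assay compound 3 gives 19100 nM. Among the measured compounds shown here, of the three values shown this is the only number, the other two sitting at a limit (the limit of > 20000 nM in this assay, at which 2 of the 3 values shown sit). The measured steps are a step that the two limits leave unreadable from compound 1 to compound 2, an at least 1.0-fold lower number from compound 1 to compound 3 (0.01 log units; that floor lies within the scatter) and an at least 1.0-fold lower number from compound 2 to compound 3 (0.01 log units; that floor lies within the scatter); none of them can be read beyond the scatter. Compound 4 `C=C1C[C@]23C[C@@]1(O)CC[C@H]2c1cc(Br)c(O)c(C)c1[C@@H]3Cn1cc(-c2ccc(F)cc2)nn1` differs from compound 3 by fluoro in place of chloro on an aromatic carbon. For the measured compounds named here, only the step from compound 2 to compound 3 concerns a halogen on that phenyl, and it lies at the scatter floor. For compound 4 no step beyond the scatter is therefore expected, a 1.0-fold higher number from compound 3 to compound 4 (0.02 log units; within the scatter). Compound 4 is expected near 20000 nM in this assay, between 8000 nM and 50000 nM, with a real chance that only a limit is returned.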

Compound 4, half-maximal inhibitory concentration: > 20000 nM
Compound 4 ended at the assay's limit; the forecaster's own chance of this, stated with the estimate: 60%; the middle value sits exactly at the limit.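

Fluoro in place of chloro on this aryl ring gives an at least 1.0-fold higher number from compound 3 to compound 4 (0.01 log units; that floor lies within the scatter) in this assay, so exchanging one halogen for the other shows no readable shift. The steps from compound 1 and from compound 2 to compound 4 cannot be read, both ends being limits. Compound 3 stays the only compound here with a number, and no group shown at this place moves the series clear of the limit: the limit of > 20000 nM in this assay, at which 3 of the 4 values shown sit.

Open, going by these compounds, is whether this position can give a readable step at all, for instance with an amine or a carboxylic acid on the aryl ring, or a longer chain in place of it. Also open, on these data alone, is where compound 1, compound 2 and compound 4 would read beyond the limit.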